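A few compounds are considered here, and "the series" means these few. Any claim that something is new, unique, unknown or untested is made for them only; others in the source may bear on it.

Measured compounds:
compound 1, `COc1cccc(-c2ccc(C(=O)N(Cc3cccc(OCCCCCC(=O)O)c3)C(C)C)cc2)c1`, in an ADME assay on HEK293 cells (Homo sapiens) for cytotoxicity, read by CellTiter-Glo and resazurin assay, with a stated time of 72 h (on this read-out lower numbers stand for an effect already at smaller amounts and higher numbers for an effect only at larger amounts of compound), gives > 20900 nM, which is a limit of the assay rather than a number.
compound 2, `CC(C)N(Cc1cccc(OCCCCCC(=O)O)c1)C(=O)c1ccc(-c2ccc(Cl)c(Cl)c2)cc1`, in this assay gives > 26000 nM, again a limit of the assay.
compound 3, `CCOC(=O)CCCCCOc1cccc(CN(C(=O)c2ccc(-c3cccnc3)cc2)C(C)C)c1`, in this assay gives > 26000 nM, also a limit of the assay.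

Going by the values given here, compound 3 therefore stands at a limit, and the two further values shown are limits as well, so no compound among the three has a measured number in this assay. Among the compounds with values here, the only step between two measured compounds that differ in one place, a step that the two limits leave unreadable from compound 1 to compound 2, cannot be read because both ends sit at limits; this is what the limit of > 20900 nM in this assay, at which 1 of the 3 values shown sits, and the limit of > 26000 nM in this assay, at which 2 of the 3 values shown sit, together show.

The next compound, compound 4, `CCOC(=O)CCCCCOc1cccc(CN(C(=O)c2ccc(-c3cccc(OC(F)(F)F)c3)cc2)C(C)C)c1`, differs from compound 3 in one place: 3-(trifluoromethoxy)phenyl in place of pyridin-3-yl on an aromatic carbon. Within the data shown here, no measured step bears on this exchange, and the one step that is available is unreadable, so the data give no direction and no size for the change in this assay. The expectation is that compound 4 will again sit at the limit of the assay, with an expected step that the limit leaves unreadable from compound 3 to compound 4. Compound 4 is therefore estimated at 30000 nM in this assay, in a range from 10000 nM to 100000 nM.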

Compound 4, half-maximal effective concentration: > 26000 nM
Compound 4: no number, only a limit; the forecaster's own chance of this, stated with the estimate: 80%; the middle value does not contradict the limit.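

Going by these compounds alone, compound 3 and compound 4 both sit at a limit of this assay rather than at a number, so the exchange of pyridin-3-yl for 3-(trifluoromethoxy)phenyl gives no step that can be read. The compounds shown leave open at what concentration, if any, each would affect these cells, and whether the exchanged groups change that concentration.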